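The source may hold more compounds than are shown below. What is called first, only, known or untested is meant among the compounds shown, and "the series" means these compounds.

In a functional assay on DU-145 cells (Homo sapiens) for inhibition, read by trypan blue exclusion, with a stated time of 96 h (on this read-out higher numbers stand for weaker inhibition of growth and lower numbers for stronger inhibition of growth), compound 1 `O=C(/C(=C\c1ccccc1OCc1ccccc1)Sc1ccc(F)cc1)c1ccc(Cl)cc1` gives 1000 nM. Compound 2 `O=C(/C(=C\c1ccccc1OCc1ccccc1)S(=O)(=O)c1ccc(F)cc1)c1ccc(Cl)cc1` carries a sulfonyl group where compound 1 carries a sulfanyl group, and compound 2 gives 1000 nM. It therefore stands level with compound 1, and the measured step, no change at the digits printed from compound 1 to compound 2 (within the scatter), lies within the scatter. Compound 3 `O=C(/C(=C\c1ccccc1OCc1ccccc1)S(=O)(=O)Cc1ccc(F)cc1)c1ccc(Cl)cc1` has not yet been measured in this assay. It departs from compound 2 at one place: 4-fluorobenzyl in place of 4-fluorophenyl on a sulfonyl sulfur. In words, 4-fluorobenzyl stands in place of 4-fluorophenyl on a sulfonyl sulfur. Going by the values given here, no measured pair tests this exchange directly. Among the compounds with values here, the only step available, no change at the digits printed from compound 1 to compound 2 (within the scatter), concerns the sulfur rather than the group attached to it, so it bears on the new change only indirectly. It offers no reason to expect a shift in either direction, but a single flat step is thin evidence and the range must stay wide. The expected change is a 1.3-fold lower number from compound 2 to compound 3 (0.10 log units; within the scatter), which would not go beyond the scatter. Compound 3 is estimated at 800 nM, with an expected range from 250 nM to 3000 nM.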

Compound 3, concentration for 50% growth inhibition: 10000 nM
Compound 3: middle estimate off by 13-fold (1.10 log units), on the low side; the measured number lies above the stated range.
By their numbers in this assay, from the lowest: compounds 1 and 2 (each within the scatter of the next); then compound 3.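

In this assay the sulfonyl sulfur proves sensitive to the group it carries: 4-fluorobenzyl in place of 4-fluorophenyl gives a 10-fold higher number from compound 2 to compound 3 (1.00 log units; beyond the scatter) and so weaker inhibition of growth, although both groups hold one six-membered aromatic ring of carbon only, one fluorine and no hydrogen-bond donors or acceptors, and the entering group is larger by a single carbon. The earlier pair changed only the sulfur and left the number flat, whereas this change moves the read-out beyond the scatter, and the same gap appears as a 10-fold higher number from compound 1 to compound 3 (1.00 log units; beyond the scatter) when the (4-fluorobenzyl)sulfonyl group is set against the (4-fluorophenyl)sulfanyl group. Nothing available here offers an explanation for this step.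

The compounds shown leave open whether 4-fluorobenzyl on a sulfanyl sulfur would behave as it does on the sulfonyl sulfur. They also leave open whether the number would climb further with a longer chain ending in the same 4-fluorophenyl ring, or how an amine on the sulfonyl sulfur would read.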